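The source may hold more compounds than are shown below. What is called first, only, known or untested is meant among the compounds shown, and "the series" means these compounds.

Compound 1, `O=C(COc1ccc(C(=O)/C=C/c2cccc(Cl)c2)cc1)N[C@H]1CCOC1=O`: 4990 nM
Compound 2, `COc1ccccc1/C=C/C(=O)c1ccc(OCC(=O)N[C@H]2CCOC2=O)cc1`: 7240 nM

In a functional assay on PC-3 cells (Homo sapiens) for antiproliferative activity, read by MTT assay, with a stated time of 72 h (a higher number here means a weaker inhibitor, a lower number a stronger inhibitor), compound 1 gives 4990 nM, and compound 2 gives 7240 nM. Compound 2 thus carries the larger of the two numbers on record, but the step of a 1.5-fold higher number from compound 1 to compound 2 (0.16 log units; within the scatter) lies within the scatter, so the two compounds cannot be told apart on this evidence.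

Compound 3, `CC(C)c1ccc(/C=C/C(=O)c2ccc(OCC(=O)N[C@H]3CCOC3=O)cc2)cc1`, is the next variation on the same core. It differs from compound 2 in one place: 4-isopropylphenyl in place of 2-methoxyphenyl on a double-bonded chain carbon bound to a double-bonded chain carbon. Among the measured compounds shown here, the only measured step that bears on this change is a 1.5-fold higher number from compound 1 to compound 2 (0.16 log units; within the scatter), which also exchanged one aryl group for another on the same double-bonded chain carbon and left the number essentially unchanged. For the measured compounds named here, no measured compound carries an isopropyl group, so the effect of that group itself is unknown here.

On this basis no step beyond the scatter is expected from compound 2 to compound 3, in either direction, with the estimate a 1.1-fold lower number from compound 2 to compound 3 (0.05 log units; within the scatter). Compound 3 is therefore expected to give about 6500 nM in this assay, within a range from 2500 nM to 17000 nM.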

Compound 3, half-maximal inhibitory concentration: 4660 nM
Estimate against measurement, compound 3: 1.4-fold (0.14 log units) above; the measured number falls inside the stated range.
By their numbers in this assay, from the lowest: compounds 3, 1 and 2 (each within the scatter of the next).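

In this assay, 4-isopropylphenyl on a double-bonded chain carbon bound to a double-bonded chain carbon gives a 1.6-fold lower number from compound 2 to compound 3 (0.19 log units; within the scatter) and a 1.1-fold lower number from compound 1 to compound 3 (0.03 log units; within the scatter), so the new group cannot be told apart from either earlier aryl group. Where the earlier pair compared only 3-chlorophenyl and 2-methoxyphenyl, this result adds a group of carbon only: the exchange removes the single hydrogen-bond acceptor of 2-methoxyphenyl and still produces no step beyond the scatter, so at this position three different substituted phenyl groups now lie within the scatter of one another. Nothing available here offers a measured explanation for this flat result.

The compounds shown leave open whether any group at this position can move the number beyond the scatter, since all three are phenyl rings carrying one substituent and none bears an amine or a carboxylic acid. They also leave open what the unsubstituted phenyl group would give, and whether the same substituent placed elsewhere on the ring would give a different number, since each of the three differs from the others in both substituent and its location.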